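The source may hold more compounds than are shown below. What is called first, only, known or untested is meant among the compounds shown, and "the series" means these compounds.

In an ADME assay on MT4 cells (Homo sapiens) for activation, read by MTT assay (a lower number here means that less compound is tolerated, a higher number that more compound is tolerated), the measured compounds stand as follows, each value a limit and not a number:
compound 1 `CCCCSc1nc(C(C)c2c(F)cccc2Cl)c(C)c(=O)[nH]1` gives > 1500 nM as a limit
compound 2 `CCc1c(C(C)c2c(F)cccc2Cl)nc(SC(C)C)[nH]c1=O` gives > 3000 nM as a limit
compound 3 `CCCSc1nc(C(C)c2c(F)cccc2Cl)c(CC)c(=O)[nH]1` gives > 3000 nM as a limit

Compound 3 holds no readable number, and its place is the limit of > 3000 nM in this assay, at which 2 of the 3 values shown sit, in this series. Compound 4 `CCCCSc1nc(C(C)c2c(F)cccc2Cl)c(CC)c(=O)[nH]1` differs from compound 3 by methyl in place of hydrogen on a saturated chain carbon, three bonds along the chain from a sulfur with methyl in place of hydrogen on a saturated chain carbon, three bonds along the chain from a sulfur, which reads as propyl to butyl. Within the data shown here, the one measured step that bears on this is a step that the two limits leave unreadable from compound 2 to compound 3 and it also changes the chain on a sulfur, yet it gives no size to carry over. Compound 1 also carries butyl on a sulfur and gives > 1500 nM as a limit, so it offers no number either. No step beyond the scatter is therefore expected in this assay and no direction can be named. The expected step is a number no higher from compound 3 to compound 4 (the limit leaves the size open) as estimated here. Compound 4 is estimated at 3000 nM with an expected range from 1500 nM to 10000 nM and may well come out as a limit again.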

Compound 4, half-maximal cytotoxic concentration: > 3000 nM
Compound 4 gave a limit, no number; the forecaster's own chance of this, stated with the estimate: 80%; the middle value lies on the limit itself.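

In this assay all four values are limits and not numbers, so the steps from compound 1, compound 2 and compound 3 to compound 4 cannot be read. The compounds shown leave open whether changing the chain on the sulfur shifts the tolerated concentration at all.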